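Swapping the Aryl Group on the Cyclopropane of Compound 2

This account rests on a few compounds, and the source may have more. Where it says the series, first, only, none or still open, it means among the compounds named here.

Among the measured compounds shown here, in a functional assay for agonist activity at G protein-coupled receptor 88 (Homo sapiens), read by HTRF and cAMP accumulation (on this read-out higher numbers stand for an effect only at larger amounts of compound and lower numbers for an effect already at smaller amounts), compound 1 `CC(C)C[C@H](N)CCN(C(=O)[C@@H]1C[C@H]1c1ccccc1)c1ccc(-c2ccccc2)cc1` gives 3 nM, while compound 2 `CC[C@H](C)[C@H](N)CN(C(=O)[C@@H]1C[C@H]1c1ccc(Cl)cc1)c1ccc(-c2ccccc2)cc1` gives 4300 nM, the higher of the two numbers measured so far. Compound 3 `CC[C@H](C)[C@H](N)CN(C(=O)[C@@H]1C[C@H]1c1c(F)cccc1F)c1ccc(-c2ccccc2)cc1` keeps the whole of compound 2 apart from one change: 2,6-difluorophenyl in place of 4-chlorophenyl on a saturated ring carbon. For the measured compounds named here, no measured pair shows what such a change does here, so only a modest step is expected, a 1.4-fold lower number from compound 2 to compound 3 (0.16 log units; within the scatter), with no clear direction. Compound 3 is therefore estimated at 3000 nM in this assay, with a likely range from 600 nM to 15000 nM.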

Compound 3, half-maximal effective concentration: 11000 nM
For compound 3 the middle estimate is 3.7-fold (0.56 log units) below the measured one; measured number inside the range.
By their numbers in this assay, from the lowest: compound 1; then compound 2; then compound 3.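

In this assay, the aryl group on this saturated ring carbon is not a neutral choice: 2,6-difluorophenyl in place of 4-chlorophenyl gives a 2.6-fold higher number from compound 2 to compound 3 (0.41 log units; beyond the scatter) and so raises the number. Both groups count the same hydrogen-bond donors and acceptors, so those counts do not separate them. Nothing measured here gives a reason for the step.

Still open, from the compounds shown here alone, is whether the kind of halogen or its place on the phenyl ring matters more. A single fluorine or a methoxy group on that ring would help to separate the two.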